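The compounds below may be only part of what the source reports. "The series", "measured", "known", "first", "only" and "open" are said of these compounds alone.

Measured compounds:
Compound 1 `O=C(CN1CCN(c2ccccn2)CC1)Nc1cccnc1` in an assay on cells for antagonist activity at D(4) dopamine receptor (Homo sapiens), read by luminescence and beta-arrestin recruitment, with a stated time of 90 min (a higher number here means a weaker inhibitor, a lower number a stronger inhibitor), gives 25800 nM.
Compound 2 `CCc1cccc(NC(=O)CN2CCN(c3ccc(Cl)cn3)CC2)c1` in this assay gives 10400 nM.
Compound 3 `O=C(CN1CCN(c2ccccn2)CC1)Nc1cncnc1` in this assay gives "not active" (no number reported).

The series sits at the weak end of this assay throughout. Among the measured compounds shown here, compound 3 is the one without a number: in this assay compound 3 came back as "not active" (no number reported), so it stands below the other two, which are themselves weak, with no single value to anchor it.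

Compound 4 `O=C(CN1CCN(c2ccc(Cl)cn2)CC1)Nc1cncnc1` is the next step from compound 3. The change is chloro in place of hydrogen on an aromatic carbon. For the measured compounds named here, no pair of measured compounds shares this exact change alone, so its effect is not known from the data; compound 2 carries the chloro together with a second change and gives 10400 nM, which says nothing clean about the chloro by itself.

For compound 4 the step in this assay is expected to be small or none beyond the scatter, with compound 4 likely to remain weak or again give no number. Compound 4 is estimated at 30000 nM, in the range 8000 nM to 100000 nM.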

Compound 4, half-maximal inhibitory concentration: > 100000 nM
Compound 4 gave a limit, no number; the forecaster's own chance of this, stated with the estimate: 55%; middle value at least 3.3-fold (0.52 log units) away from the limit.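

Compound 4 in this assay gives > 100000 nM, a limit and not a number: the limit of > 100000 nM in this assay, at which 1 of the 4 values shown sits.

Among the compounds shown here, with 5-chloropyridin-2-yl held constant, pyrimidin-5-yl in place of 3-ethylphenyl on the amide-type nitrogen gives an at least 9.6-fold higher number from compound 2 to compound 4 (0.98 log units; beyond the scatter), the first clean reading at this position. The change from pyridin-2-yl to 5-chloropyridin-2-yl cannot be read as a step, since neither compound 3 nor compound 4 has a number, but the chloro does not bring the pyrimidin-5-yl amide to a measurable value.

From the compounds shown here alone, the effect of the chloro remains open on an amide that gives a number, such as that of compound 1. Also open, going by these compounds, is whether a methoxy or a longer chain in place of the ethyl of compound 2 would move the value in this assay.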